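The compounds below may be only part of what the source reports. "The series", "measured", "known", "first", "only" and "open" are said of these compounds alone.

Two amides that share one core have been measured in a functional assay on A549 cells (Homo sapiens) for cytotoxicity, read by MTT assay, with a stated time of 68 h; on this read-out higher numbers stand for weaker inhibition and lower numbers for stronger inhibition. Compound 1 `O=C(Nc1cccc(-c2ccccc2C(F)(F)F)c1)C(Cl)Cl` carries a trifluoromethyl group, and in this assay compound 1 gives 7500 nM. Compound 2 `Cc1cccc(-c2cccc(NC(=O)C(Cl)Cl)c2)c1` carries a methyl group in its place, and in this assay compound 2 gives 8700 nM. Compound 2 stands at the higher of the two numbers, yet its gap to compound 1 lies within the usual scatter of repeated measurements, so the two values tell the same story and neither compound can be called the weaker.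

Compound 3 `O=C(Nc1cccc(-c2ccccc2)c1)C(Cl)Cl` has not yet been measured in this assay. It differs from compound 2 in a single place: hydrogen in place of methyl on an aromatic carbon. For the measured compounds named here, the methyl leaves and a hydrogen enters on an aromatic carbon; no measured pair shows how such a swap moves the number here. With compound 1 and compound 2 sitting so close together despite different groups, the expectation for this assay is a step of no size beyond the scatter, in either direction. Compound 3 is therefore estimated at 9000 nM, with a range from 3500 nM to 25000 nM, meaning an expected step of a 1.0-fold higher number from compound 2 to compound 3 (0.01 log units; within the scatter).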

Compound 3, half-maximal inhibitory concentration: 8900 nM
Compound 3: the middle estimate sits 1.0-fold (0.00 log units) above what was measured; the range from low to high includes it.
By their numbers in this assay, from the lowest: compounds 1, 2 and 3 (each within the scatter of the next).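

Compound 3 adds something the first two compounds could not give: a reference with plain hydrogen on the aromatic carbon, so that each substituent can now be set against having no substituent at all. In this assay, the swap of methyl for hydrogen, on an aromatic carbon meta to a large group, gives a 1.0-fold higher number from compound 2 to compound 3 (0.01 log units; within the scatter), and the swap of trifluoromethyl for hydrogen gives a 1.2-fold higher number from compound 1 to compound 3 (0.07 log units; within the scatter), so neither step can be told apart from repeat-measurement noise, and among these three compounds neither methyl nor trifluoromethyl sets its compound apart from the one carrying hydrogen. Nothing available here offers an independent measurement that would explain this flat result.

The compounds shown leave open whether an amine or a carboxylic acid on the same aromatic carbon would give a number clearly apart from these three. As far as these compounds go, all three also carry the same amide with its two chlorine atoms, so what that part of the shared core contributes in this assay remains unknown.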